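A few compounds are considered here, and "the series" means these few. Any claim that something is new, unique, unknown or untested is made for them only; others in the source may bear on it.

Working notes on the series

The shared core is carried by compound 1 `CNC(=O)c1nc(-c2cccs2)[nH]c(=O)c1O`, compound 2 `CCCNC(=O)c1nc(-c2cccs2)[nH]c(=O)c1O` and compound 3 `O=C(c1nc(-c2cccs2)[nH]c(=O)c1O)N1CCCC1`. In an assay on isolated protein for inhibition of Flap endonuclease 1 (Homo sapiens) (a higher number here means a weaker inhibitor, a lower number a stronger inhibitor), compound 1 gives 12000 nM, compound 2 gives 4200 nM and compound 3 gives 13700 nM. Among the three numbers compound 3 stands highest; compound 1 is nearest to it, and the two lie within the scatter a 1.1-fold higher number from compound 1 to compound 3 (0.06 log units; within the scatter), while the distance to compound 2 is beyond it a 3.3-fold higher number from compound 2 to compound 3 (0.51 log units; beyond the scatter). Within the data shown here, the one step that clears the scatter is a 2.9-fold lower number from compound 1 to compound 2 (0.46 log units; beyond the scatter).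

Compound 4 `CCC(C)NC(=O)c1nc(-c2cccs2)[nH]c(=O)c1O` has not yet been measured in this assay. It differs from compound 3 in that ((sec-butyl)amino in place of pyrrolidin-1-yl on a carbonyl carbon). The step that bears most directly on this change is a 3.3-fold higher number from compound 2 to compound 3 (0.51 log units; beyond the scatter), which runs in the opposite direction from a ring to an open chain with one hydrogen-bond donor, and a 1.1-fold higher number from compound 1 to compound 3 (0.06 log units; within the scatter) shows that the ring and the shortest chain gave numbers within the scatter. A (sec-butyl)amino group is an open chain of the longer kind, so the expectation is a modest lower number in this assay, roughly the reverse of the step from compound 2 to compound 3, with the branching of the chain untested and therefore widening the range. For compound 4 the estimated step is a 2.7-fold lower number from compound 3 to compound 4 (0.44 log units; beyond the scatter). Compound 4 is accordingly expected to give about 5000 nM, within a range from 2000 nM to 14000 nM.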

Compound 4, half-maximal inhibitory concentration: 1300 nM
Beside the measured number, compound 4's estimate is 3.8-fold (0.59 log units) above it; measured number below the stated range.
By their numbers in this assay, from the lowest: compound 4; then compound 2; then compounds 1 and 3 (each within the scatter of the next).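

In this assay, among these compounds, the exchange of pyrrolidin-1-yl for (sec-butyl)amino on a carbonyl carbon leaves the heavy-atom count unchanged yet gives an 11-fold lower number from compound 3 to compound 4 (1.02 log units; beyond the scatter) and is the largest step so far, so this position responds strongly to a change that opens the ring and brings in 1 hydrogen-bond donor, though the two features change together and cannot be told apart here. Among the open chains, the number keeps falling: the added methyl on the saturated chain carbon gives a 3.2-fold lower number from compound 2 to compound 4 (0.51 log units; beyond the scatter) and the full exchange of methyl for sec-butyl on the amide-type nitrogen gives a 9.2-fold lower number from compound 1 to compound 4 (0.97 log units; beyond the scatter); the trend with chain size holds only for compound 1, compound 2 and compound 4, and compound 3 goes against it as a ring of the same size as the sec-butyl group. No measurement at hand gives a reason for any of these steps.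

The compounds shown leave open whether the branch itself matters or only the added carbon, which a straight butylamino group would address. They also leave open whether a ring with the amide hydrogen kept, such as cyclobutylamino, would behave like the open chain or like pyrrolidin-1-yl.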